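Aryl swap on a thiophene series: A3 binding unchanged so far

The compounds below may be only part of what the source reports. "The series", "measured", "known", "first", "only" and "open" are said of these compounds alone.

Compound 1 `CC(C)(C)Cc1c(-c2ccoc2)sc(N)c1C(=O)c1ccc(Cl)cc1` and compound 2 `CC(C)(C)Cc1c(-c2ccc(Cl)c(Cl)c2)sc(N)c1C(=O)c1ccc(Cl)cc1` share the same core and differ only in the aryl group on the ring carbon next to the sulfur. In an assay on CHO cells for displacement of a labelled ligand from adenosine receptor A3 (Homo sapiens), read by scintillation counting, tested at 10 uM (a lower number here means less inhibition, a higher number more inhibition at the concentration tested (going by the name of the read-out)), compound 1 gives 1%, and in this assay compound 2 gives 1%. The step of no change at the digits printed from compound 1 to compound 2 (within the scatter) thus shows that replacing furan-3-yl by 3,4-dichlorophenyl left the read-out where it was, so compound 2 stands level with compound 1.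

Compound 3 `COc1cccc(-c2sc(N)c(C(=O)c3ccc(Cl)cc3)c2CC(C)(C)C)c1` is not yet measured. It differs from compound 2 by 3-methoxyphenyl in place of 3,4-dichlorophenyl on an aromatic carbon. Going by the values given here, the only step that bears on this change is the one from compound 1 to compound 2, which stayed within the scatter, so another aryl exchange at the same place is expected to give no change beyond the scatter in this assay, estimated as a number 1 percentage points higher from compound 2 to compound 3 (within the scatter). Compound 3 is therefore expected to give about 2%, between 0% and 12%.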

Compound 3, a percentage reported as inhibition, at one concentration (the size of the read-out at that concentration, not a potency): 1%
Estimate against measurement, compound 3: 1 percentage points above; the measured number falls inside the stated range.
By their numbers in this assay, from the lowest: compounds 1, 2 and 3 (each within the scatter of the next).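

In this assay, the exchange of 3,4-dichlorophenyl for 3-methoxyphenyl, which brings in oxygen and a hydrogen-bond acceptor and removes both chlorines, gives no change at the digits printed from compound 2 to compound 3 (within the scatter), and the exchange of furan-3-yl for the same group gives no change at the digits printed from compound 1 to compound 3 (within the scatter). The aryl place next to the ring sulfur has now taken a furan, a chlorinated phenyl and a methoxylated phenyl with no step beyond the scatter, and the added hydrogen-bond acceptor shifts nothing at the digits printed. No measurement at hand explains this flat outcome.

As far as these compounds go, it remains open whether a group that is not an aryl at this place, such as a carboxylic acid, an amine or a longer alkyl chain, would move the read-out. From the compounds shown here alone, the neopentyl, (4-chlorophenyl)carbonyl and amino groups are the same in all three compounds, so their part in the read-out also stays open.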